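A few compounds are considered here, and "the series" means these few. Any claim that something is new, unique, unknown or untested is made for them only; others in the source may bear on it.

In a functional assay on MCF7 cells (Homo sapiens) for inhibition, read by MTT assay (on this read-out higher numbers stand for weaker inhibition and lower numbers for stronger inhibition), compound 1 `COc1cc2ncnc(Nc3ccc(NC(=O)c4cccc(C)c4)cc3)c2cc1OC` gives 13000 nM. Compound 2 `COc1cc2ncnc(Nc3ccc(NC(=O)c4ccc(C)cc4)cc3)c2cc1OC` gives 19000 nM, and the result is a 1.5-fold higher number from compound 1 to compound 2 (0.16 log units; within the scatter), so these two compounds stand level. Compound 3 `COc1cc2ncnc(Nc3ccc(NC(=O)c4ccccc4OC)cc3)c2cc1OC` reports only a limit, > 100000 nM.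

Compound 4 `COc1cc2ncnc(Nc3ccc(NC(=O)c4ccccc4F)cc3)c2cc1OC` has not yet been measured. It carries 2-fluorophenyl in place of 3-methylphenyl on a carbonyl carbon.

Two measured steps offer guidance. Exchanging one methylphenyl group for another gave a 1.5-fold higher number from compound 1 to compound 2 (0.16 log units; within the scatter), while bringing in 2-methoxyphenyl gave an at least 7.6-fold higher number from compound 1 to compound 3 (0.88 log units; beyond the scatter). Within the data shown here, the second is the closer guide, since 2-fluorophenyl and 2-methoxyphenyl have names of the same form, but fluorine and methoxy are different groups and this is only one comparison. Among the measured compounds shown here, a higher number, meaning weaker inhibition, is therefore expected in this assay, though probably a smaller change than the one seen with compound 3.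

The expected change is a 2.3-fold higher number from compound 1 to compound 4 (0.36 log units; beyond the scatter). For compound 4, the estimated value is 30000 nM, with an expected range from 10000 nM to 90000 nM.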

Compound 4, half-maximal inhibitory concentration: 11000 nM
The estimate for compound 4 lay 2.7-fold (0.44 log units) above the measured number, within the range that was stated.
By their numbers in this assay, from the lowest: compounds 4, 1 and 2 (each within the scatter of the next). At a limit, above all of these: compound 3.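

The 2-fluorophenyl group stands level with both methylphenyl groups in this assay, with a 1.2-fold lower number from compound 1 to compound 4 (0.07 log units; within the scatter) and a 1.7-fold lower number from compound 2 to compound 4 (0.24 log units; within the scatter). A group on the phenyl ring named at its 2-position therefore does not bring the loss on its own, and the identity of that group matters: fluoro in place of methoxy on an aromatic carbon gives an at least 9.0-fold lower number from compound 3 to compound 4 (0.95 log units; beyond the scatter). The size of that last step is open-ended, since the value of compound 3 is a limit and not a number: the limit of > 100000 nM in this assay, at which 1 of the 4 values shown sits.

Going by these compounds, whether 2-chlorophenyl, 2-hydroxyphenyl or 2-aminophenyl would follow 2-fluorophenyl or 2-methoxyphenyl remains open. So does whether a 3-fluorophenyl or 4-fluorophenyl group on the same carbonyl carbon would give a similar number.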